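Dropping One Methoxy Group: From Compound 2 to Compound 3

The compounds below may be only part of what the source reports. "The series", "measured", "known", "first", "only" and "open" are said of these compounds alone.

Two measured compounds share one core and differ only in the ring attached to the carbonyl. Compound 1 `O=C(/C=C/c1cn(-c2ccccc2)nc1-c1ccncc1)c1ccsc1` carries a thiophene ring there, and in a functional assay on MCF7 cells (Homo sapiens) for inhibition, read by sulforhodamine B assay, with a stated time of 72 h (a lower number here means a stronger inhibitor, a higher number a weaker inhibitor), compound 1 gives 1500 nM. Compound 2 `COc1ccc(C(=O)/C=C/c2cn(-c3ccccc3)nc2-c2ccncc2)c(OC)c1OC` carries instead a benzene ring bearing three methoxy groups, and in this assay compound 2 gives 3300 nM. Of these two numbers, compound 2 stands at the higher one, so it is the weaker inhibitor of the pair, and the gap between the two values is beyond the usual scatter.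

Compound 3 `COc1ccc(C(=O)/C=C/c2cn(-c3ccccc3)nc2-c2ccncc2)c(OC)c1` keeps everything in compound 2 except one group: hydrogen in place of methoxy on an aromatic carbon. For the measured compounds named here, no measured pair shows the loss of a single methoxy group, so there is no direct guide to the size of this step. Removing a small group from a ring that already carries two others is expected to move the number little, if at all, most likely within the scatter. The expected step of a 1.1-fold lower number from compound 2 to compound 3 (0.04 log units; within the scatter) is therefore small. For compound 3 in this assay the estimate is 3000 nM, with a range from 1200 nM to 8000 nM.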

Compound 3, half-maximal inhibitory concentration: 8800 nM
Beside the measured number, compound 3's estimate is 2.9-fold (0.47 log units) below it; measured number above the stated range.
By their numbers in this assay, from the lowest: compound 1; then compound 2; then compound 3.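

Replacing the methoxy group that stands ortho to two methoxy groups with hydrogen gives a 2.7-fold higher number from compound 2 to compound 3 (0.43 log units; beyond the scatter) in this assay, so this single group counts: compound 2, which keeps it, is the stronger inhibitor, and the change reaches beyond the scatter even though the ring still carries two other methoxy groups. The comparison with the thiophene compound gives a 5.9-fold higher number from compound 1 to compound 3 (0.77 log units; beyond the scatter) for 2,4-dimethoxyphenyl in place of thiophen-3-yl on the carbonyl carbon, which makes compound 3 the weakest inhibitor of the three, since its steps to both others lie beyond the scatter. Nothing in the available data explains why losing this methoxy group weakens inhibition.

The compounds shown leave open whether another group at this place, such as a hydroxyl group, an ethoxy group or an amine, would match methoxy or differ from it. They also leave open whether removing either of the other two methoxy groups from compound 2 would produce a step of similar size, or whether this place on the ring is unusual.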